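Swapping fluoro for nitro on a cinnamyl-type side chain

The source may report more compounds than this note shows. Statements on the series, on what has been measured and on what is new or still open speak of the compounds shown alone.

Measured so far:
Compound 1 `O=[N+]([O-])c1ccc(/C=C/C[C@H]2C[C@@H]([C@@H](O)c3ccccc3)CO[C@@H]2c2ccccc2)cc1`: 12400 nM
Compound 2 `O[C@@H](c1ccccc1)[C@H]1CO[C@H](c2ccccc2)[C@@H](C/C=C/c2ccc(F)cc2)C1`: 8340 nM
Compound 3 `O[C@@H](c1ccccc1)[C@H]1CO[C@H](c2ccccc2)[C@@H](C/C=C/c2ccccc2F)C1`: 9730 nM

All three were tested in a functional assay on HeLa cells (Homo sapiens) for cytotoxicity, read by WST assay, with a stated time of 48 h; a higher number here means a weaker inhibitor, a lower number a stronger inhibitor. The change from compound 2 to compound 1 is nitro in place of fluoro on an aromatic carbon and it gave a 1.5-fold higher number from compound 2 to compound 1 (0.17 log units; within the scatter). Compound 4 `O=[N+]([O-])c1ccccc1/C=C/C[C@H]1C[C@@H]([C@@H](O)c2ccccc2)CO[C@@H]1c1ccccc1` is not yet measured; it differs from compound 3 by nitro in place of fluoro on an aromatic carbon. The cores of compound 2 and compound 3 differ by 2-fluorophenyl in place of 4-fluorophenyl on a double-bonded chain carbon bound to a double-bonded chain carbon, so the two cores are not identical. The place of the change also differs in its surroundings: in compound 2 the carbon is para to a large group, in compound 3 it is ortho to a large group, so the change is the same kind of change, not the same. Because a 1.5-fold higher number from compound 2 to compound 1 (0.17 log units; within the scatter) stayed within the scatter, the step from compound 3 to compound 4 is expected to be small as well, estimated at a 1.3-fold higher number from compound 3 to compound 4 (0.11 log units; within the scatter). On that basis compound 4 is expected to give about 12500 nM, with a likely range from 6500 nM to 25000 nM.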

Compound 4, half-maximal inhibitory concentration: 11800 nM
Beside the measured number, compound 4's estimate is 1.1-fold (0.03 log units) above it; measured number inside the range.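

In this assay, nitro in place of fluoro gave steps of matching size on the two cores: the same change on two cores in this assay, a 1.5-fold higher number (0.17 log units; within the scatter) from compound 2 to compound 1 and a 1.2-fold higher number (0.08 log units; within the scatter) from compound 3 to compound 4, 1.2-fold (0.09 log units) apart, within the scatter of two such steps

The new step (a 1.2-fold higher number from compound 3 to compound 4 (0.08 log units; within the scatter)) agrees with the two other new comparisons (a 1.4-fold higher number from compound 2 to compound 4 (0.15 log units; within the scatter)) and (a 1.1-fold lower number from compound 1 to compound 4 (0.02 log units; within the scatter)), so all four compounds lie within the scatter of one another. Going by these compounds, this shows that the swap made no readable difference on either core, but with steps this small it does not show that any real effect of the swap carries from one core to the other, and these two cores differ only in 2-fluorophenyl against 4-fluorophenyl, so a more distant core remains untested here.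

The compounds shown leave open whether any other group on this aromatic ring, such as an amine or a carboxylic acid, would move the number beyond the scatter. They also leave open whether a longer chain between that ring and the shared core would change the picture.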